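The source may report more compounds than this note shows. Statements on the series, on what has been measured and on what is new or still open speak of the compounds shown alone.

Measured compounds:
- compound 1 `COC(=O)C1=C(C)N=C(C)/C(=C(\O)OC)C1c1cccc(N)c1`: 2000 nM
- compound 2 `COC(=O)C1=C(C)N=C(C)/C(=C(\O)OC)C1c1cccc(C(F)(F)F)c1`: 74.1 nM

In a functional assay (muscle tissue) with Cavia porcellus as the target (a higher number here means that more compound is needed for the effect, a lower number that less compound is needed), compound 1 gives 2000 nM, the highest of the two numbers; its nearest neighbour is compound 2 with 74.1 nM. Among the measured compounds shown here, the one measured step, a 27-fold lower number from compound 1 to compound 2 (1.43 log units; beyond the scatter), is large and beyond the scatter.

Compound 3 `COC(=O)C1=C(C)N=C(C)/C(=C(\O)OC)C1c1ccccc1C` differs from compound 1 by 2-methylphenyl in place of 3-aminophenyl on a saturated ring carbon. For the measured compounds named here, no measured step covers this change directly; the step from compound 1 to compound 2 is the only one that bears on it, and it shows that removing the amino group from the shared core gives a much lower number in this assay. The incoming 2-methylphenyl also has no amino group, so a lower number than compound 1 is expected, though with less certainty than for compound 2. The estimate for compound 3 is 300 nM, range 60 nM to 1500 nM, corresponding to an expected step of a 6.7-fold lower number from compound 1 to compound 3 (0.82 log units; beyond the scatter).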

Compound 3, half-maximal effective concentration: 6.03 nM
For compound 3 the middle estimate is 50-fold (1.70 log units) above the measured one, and the stated range ends above it.
By their numbers in this assay, from the lowest: compound 3; then compound 2; then compound 1.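

In this assay, the replacement of 3-aminophenyl by 2-methylphenyl on the saturated ring carbon gives a 330-fold lower number from compound 1 to compound 3 (2.52 log units; beyond the scatter), a larger step than a 27-fold lower number from compound 1 to compound 2 (1.43 log units; beyond the scatter), so a low number at this position does not depend on a trifluoromethyl group. This change swaps the group and also moves the substituent to a different place on the aromatic ring, so the step cannot be assigned to either alone. Nothing available explains the size of this step.

On these data alone, it remains open whether the methyl group or its place on the aromatic ring accounts for the step, and a phenyl group without any substituent would serve as the missing reference. Also open, as far as these compounds go, is how chloro or nitro groups on that ring, or an ethyl ester in place of the methoxycarbonyl group, would read in this assay.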